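A Halogen Swap on an Aryl Ether Among Weak Inhibitors

The source may hold more compounds than are shown below. What is called first, only, known or untested is meant among the compounds shown, and "the series" means these compounds.

Compound 1 `Cc1nn(C)c(Oc2cccc(F)c2)c1/C=N\CCCCCCOc1cc2oc(=O)cc(C)c2cc1Cl` and compound 2 `Cc1nn(C)c(Oc2ccc(F)cc2F)c1/C=N\CCCCCCOc1cc2oc(=O)cc(C)c2cc1Cl` share the same core and chain and differ only in the aryl group carried on the ether oxygen. In a functional assay on HepG2 cells (Homo sapiens) for antiproliferative activity, read by MTT assay, with a stated time of 72 h (a higher number here means a weaker inhibitor, a lower number a stronger inhibitor), compound 1 gives no number but only a limit of the assay, > 25000 nM. In this assay compound 2 likewise gives only a limit, > 25000 nM. The step that the two limits leave unreadable from compound 1 to compound 2 therefore cannot be sized, because the limit of > 25000 nM in this assay, at which 2 of the 2 values shown sit, leaves both ends open. Compound 3 `Cc1nn(C)c(Oc2cccc(Cl)c2)c1/C=N\CCCCCCOc1cc2oc(=O)cc(C)c2cc1Cl` differs from compound 2 in a single place: 3-chlorophenyl in place of 2,4-difluorophenyl on an oxygen on an aromatic ring. No measured step bears readably on this change, and both measured compounds stand at the same limit, so nothing shown points to a gain in potency from the new aryl group. Compound 3 is therefore expected to behave like compound 2 in this assay, and the expected step that the limit leaves unreadable from compound 2 to compound 3 is essentially none beyond the scatter. Compound 3 is estimated at 30000 nM in this assay, with a range from 8000 nM to 100000 nM, and it is expected most probably to be reported once more only as a limit.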

Compound 3, half-maximal inhibitory concentration: 6220 nM
Estimate against measurement, compound 3: 4.8-fold (0.68 log units) above; measured number outside the range, below it.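

The 3-chlorophenyl group on the ether oxygen gives the first readable result at this place in this assay, with an at least 4.0-fold lower number from compound 2 to compound 3 (0.60 log units; beyond the scatter). The closest comparison is the exchange of chloro for fluoro on an aromatic carbon, which gives an at least 4.0-fold lower number from compound 1 to compound 3 (0.60 log units; beyond the scatter), so among the compounds shown this single halogen exchange is enough to bring the series from a limit to a measured number, and the second fluorine of the 2,4-difluorophenyl group is not part of that comparison. Both steps can be given only as minimum sizes because compound 1 and compound 2 each stand at a limit rather than a number: the limit of > 25000 nM in this assay, at which 2 of the 3 values shown sit.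

The compounds shown leave open whether bromo, trifluoromethyl or methoxy in place of chloro on that aromatic carbon would lower the number further, or whether the effect belongs to chloro alone. They also leave open whether a 3-chlorophenyl group would give a similar step with a shorter or longer chain in place of the one shared here, since only one chain appears in these compounds.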